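Taking the bromo group off compound 3

A few compounds are considered here, and "the series" means these few. Any claim that something is new, unique, unknown or untested is made for them only; others in the source may bear on it.

Three related compounds have so far been measured in a functional assay on HeLa cells (Homo sapiens) for antiproliferative activity, read by MTT assay, with a stated time of 48 h (on this read-out higher numbers stand for weaker inhibition and lower numbers for stronger inhibition), and all give numbers in the micromolar region. Compound 1 (`Brc1ccc(CSc2nnc(-c3cnccn3)o2)cc1`) gives 21600 nM and compound 2 (`Fc1ccc(CSc2nnc(-c3cnccn3)o2)c(F)c1`) gives 26700 nM as its value, and these two lie within the usual scatter of each other. Compound 3 (`Brc1cccc(CSc2nnc(-c3cnccn3)s2)c1`) gives 5430 nM as the lowest of the three numbers, and its gap to each of the other two lies beyond the scatter.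

The next compound, compound 4 (`c1ccc(CSc2nnc(-c3cnccn3)s2)cc1`), keeps the core of compound 3 and changes one place: hydrogen in place of bromo on an aromatic carbon with hydrogen in place of bromo on an aromatic carbon, meta to a large group. Among the measured compounds shown here, no measured pair shows this exchange on its own. The only hint is weak: compound 1 carries bromo and compound 2 does not, yet their values stay within the scatter, although the two differ in more than that. Compound 3 at 5430 nM holds the lowest number, so a small rise is expected rather than a further fall. The estimated step of a 1.7-fold higher number from compound 3 to compound 4 (0.22 log units; within the scatter) would stay within the scatter in this assay on this reading. For compound 4 the estimated value is 9000 nM with an expected range from 3500 nM to 25000 nM in this assay.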

Compound 4, half-maximal inhibitory concentration: 34400 nM
Compound 4: middle estimate off by 3.8-fold (0.58 log units), on the low side, and the stated range ends below it.
By their numbers in this assay, from the lowest: compound 3; then compounds 1, 2 and 4 (each within the scatter of the next).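

In this assay, hydrogen in place of bromo on an aromatic carbon, meta to a large group, gives a 6.3-fold higher number from compound 3 to compound 4 (0.80 log units; beyond the scatter). Among the compounds shown here, this is the first exchange that can be read on its own, since the earlier compounds differed from one another in more than one place and offered only a weak hint about bromo. It shows that on this core the position is not indifferent: with nothing but hydrogen there, inhibition is weaker, and the bromo accounts for the whole of the step. No measurement at hand bears on why this exchange moves the number as it does.

For the compounds shown here, the single pair cannot tell whether the gain belongs to bromo in particular or would come with any group at this place, so chloro, methoxy or an amine on the same carbon remain open. It also leaves open whether bromo on another carbon of the same ring would give a step of similar size, and whether the step would hold on a different core.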